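This account rests on a few compounds, and the source may have more. Where it says the series, first, only, none or still open, it means among the compounds named here.

Compound 3 `NS(=O)(=O)c1ccc(N2N=C(c3ccc(OCc4ccccc4)cc3)CC2c2ccccc2)cc1` gives 80000 nM in an ADME assay on BHK-21 cells (Mesocricetus auratus) for cytotoxicity, read by MTT assay, with a stated time of 72 h (on this read-out lower numbers stand for higher toxicity in this test and higher numbers for lower toxicity in this test), the highest of the three numbers in hand. Compound 1 `NS(=O)(=O)c1ccc(N2N=C(c3ccc(Oc4ccccc4)cc3)CC2c2ccccc2F)cc1` gives 32000 nM in this assay, and compound 2 `NS(=O)(=O)c1ccc(N2N=C(c3ccccc3)CC2c2ccccc2F)cc1` gives 21000 nM. Within the data shown here, the one measured step, a 1.5-fold lower number from compound 1 to compound 2 (0.18 log units; within the scatter), concerns a different change and stays within the scatter. Among the measured compounds shown here, compound 4 `NS(=O)(=O)c1ccc(N2N=C(c3ccc(OCc4ccccc4)cc3)CC2c2ccccc2F)cc1` differs from compound 3 by fluoro in place of hydrogen on an aromatic carbon; no measured pair shows this change alone, since compounds 1 and 3 differ in two places, and their values show only that compound 3 stands higher. With no step beyond the scatter anywhere in the set, compound 4 is expected to stay close to compound 3, with a 1.1-fold lower number from compound 3 to compound 4 (0.06 log units; within the scatter) as the estimated step, giving an expected value of 70000 nM in this assay, in the range 35000 nM to 140000 nM.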

Compound 4, half-maximal cytotoxic concentration: 90000 nM
Estimate against measurement, compound 4: 1.3-fold (0.11 log units) below; the range from low to high includes it.
By their numbers in this assay, from the lowest: compounds 2 and 1 (each within the scatter of the next); then compounds 3 and 4 (each within the scatter of the next).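

In this assay, fluoro in place of hydrogen, ortho to a large group, gives a 1.1-fold higher number from compound 3 to compound 4 (0.05 log units; within the scatter), so this change leaves the two compounds indistinguishable. With the 2-fluorophenyl held constant, benzyloxy in place of hydrogen gives a 4.3-fold higher number from compound 2 to compound 4 (0.63 log units; beyond the scatter), and benzyl in place of phenyl on the oxygen gives a 2.8-fold higher number from compound 1 to compound 4 (0.45 log units; beyond the scatter), which places the larger differences at the benzyloxy group rather than at the fluoro. Nothing available gives a reason for these steps.

Going by these compounds, whether chloro or methoxy at this position reads like fluoro remains open. So does whether an amine or a carboxylic acid on the benzyloxy group preserves the number.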